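A few compounds are considered here, and "the series" means these few. Any claim that something is new, unique, unknown or untested is made for them only; others in the source may bear on it.

Values measured in a functional assay on A549 cells (Homo sapiens) for cytotoxicity; on this read-out higher numbers stand for weaker inhibition and lower numbers for stronger inhibition:
Compound 1 `C=C(C(=O)O[C@@H]1/C(C)=C/[C@@]23O[C@@]2(C[C@H](C)[C@@H]3OC(C)=O)C(=O)[C@H](C)[C@H](OC(C)=O)[C@@H]2[C@H]([C@H]1OC)C2(C)C)C(C)O`: < 10000 nM
Compound 2 `C/C=C(/C)C(=O)O[C@@H]1/C(C)=C/[C@@]23O[C@@]2(C[C@H](C)[C@@H]3O)C(=O)[C@H](C)[C@H](O)[C@@H]2[C@H]([C@H]1OC)C2(C)C`: < 10000 nM

Compound 1 has no exact value, since its < 10000 nM is a limit and not a number. Compound 2 also gives only a limit, < 10000 nM. Together, the two results amount to the limit of < 10000 nM in this assay, at which 2 of the 2 values shown sit, so neither compound can be ranked against the other.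

Compound 3 `C/C=C(/C)C(=O)O[C@@H]1/C(C)=C/[C@@]23O[C@@]2(C[C@H](C)[C@@H]3OC(C)=O)C(=O)[C@H](C)[C@H](OC(C)=O)[C@@H]2[C@H]([C@H]1OC)C2(C)C` keeps the core of compound 1 and changes one group on a carbonyl carbon: a group of 4 heavy atoms (4 carbon; no ring) in place of a group of 5 heavy atoms (4 carbon, 1 oxygen; no ring), on a carbonyl carbon. Within the data shown here, no measured pair shows what this exchange does, so no step beyond the usual scatter is expected in this assay, in either direction. The expected change is a step that the limit leaves unreadable from compound 1 to compound 3. For compound 3 the estimated value is 6000 nM, with an expected range from 2000 nM to 15000 nM.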

Compound 3, half-maximal inhibitory concentration: < 10000 nM
Compound 3 gave a limit, no number; the forecaster's own chance of this, stated with the estimate: 45%; the middle value does not contradict the limit.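

No step can be read between compound 1 and compound 3, as both results are limits and not numbers: the limit of < 10000 nM in this assay, at which 3 of the 3 values shown sit. Going by these compounds, how far this exchange of groups on a carbonyl carbon shifts the value in this assay, and how the three compounds rank, stays open.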